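A few compounds are considered here, and "the series" means these few. Any claim that something is new, unique, unknown or untested is made for them only; others in the source may bear on it.

Compound 1 `N#CC1=C(N)Oc2c(c3nc4ccccc4nc3c3ccccc23)C12C(=O)N(Cc1cnnn1-c1ccc([N+](=O)[O-])cc1)c1ccccc12` and compound 2 `Cc1ccc(-n2nncc2CN2C(=O)C3(C(C#N)=C(N)Oc4c3c3nc5ccccc5nc3c3ccccc43)c3ccccc32)cc1C` share one core and differ in a single place, (3,4-dimethylphenyl in place of 4-nitrophenyl on an aromatic nitrogen). In a functional assay on A549 cells (Homo sapiens) for antiproliferative activity, read by MTT assay, with a stated time of 48 h (a lower number here means a stronger inhibitor, a higher number a weaker inhibitor), compound 1 reaches only the limit of the assay, > 50000 nM. In this assay compound 2 likewise reaches only the limit, > 50000 nM. The step that the two limits leave unreadable from compound 1 to compound 2 cannot be sized because both ends rest at the limit of > 50000 nM in this assay, at which 3 of the 3 values shown sit. Compound 3 `N#CC1=C(N)Oc2c(N)cc3nc4ccccc4nc3c2C12C(=O)N(Cc1cnnn1-c1ccc([N+](=O)[O-])cc1)c1ccccc12` carries a different core; the difference between the two cores is not broken down here. In this assay compound 3 also gives only the limit, > 50000 nM. Compound 4 `Cc1ccc(-n2nncc2CN2C(=O)C3(C(C#N)=C(N)Oc4c(N)cc5nc6ccccc6nc5c43)c3ccccc32)cc1C` differs from compound 3 by the same kind of change, (3,4-dimethylphenyl in place of 4-nitrophenyl on an aromatic nitrogen). Among the compounds with values here, the step is expected to be unreadable again, near a step that the limit leaves unreadable from compound 3 to compound 4, because every value so far sits at the limit of > 50000 nM in this assay, at which 3 of the 3 values shown sit. For compound 4 the estimate is 70000 nM, most likely reported only as a limit.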

Compound 4, half-maximal inhibitory concentration: > 50000 nM
Compound 4: no number, only a limit; the forecaster's own chance of this, stated with the estimate: 85%; the middle value is on the limit's open side.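

No step can be read between compound 3 and compound 4, because both give only a limit: the limit of > 50000 nM in this assay, at which 4 of the 4 values shown sit.

The compounds shown leave open whether 3,4-dimethylphenyl in place of 4-nitrophenyl changes activity at all in this assay.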